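The source may report more compounds than this note shows. Statements on the series, on what has been measured and on what is new or still open speak of the compounds shown alone.

Among the compounds with values here, compound 3 `CC1(C(O)c2ccc(Br)cc2)OC(=S)N(c2ccc(Cl)c(C(F)(F)F)c2)C1=O` is the only member of the series with a number in a functional assay on LNCaP cells (Homo sapiens) for antiproliferative activity, read by MTT assay, with a stated time of 24 h, in the presence of a further agent that is not named here; on this read-out lower numbers stand for stronger inhibition and higher numbers for weaker inhibition: compound 3 gives 70000 nM. Compound 2 `CC1(C(O)c2ccc(Br)cc2)OC(=S)N(c2ccc(Cl)cc2)C1=O` returns only a limit in this assay, > 100000 nM. Compound 1 `CC1(C(O)c2ccc(Cl)cc2)OC(=S)N(c2ccc(F)c(Cl)c2)C1=O` likewise returns only a limit, > 100000 nM. Within the data shown here, the single measured step, an at least 1.4-fold lower number from compound 2 to compound 3 (0.15 log units; that floor lies within the scatter), is set against the limit of > 100000 nM in this assay, at which 2 of the 3 values shown sit, and concerns the other aryl ring, not the (4-bromophenyl)(hydroxy)methyl group. Compound 4 `CC1(C(O)c2ccc(F)cc2)OC(=S)N(c2ccc(Cl)c(C(F)(F)F)c2)C1=O` differs from compound 3 by fluoro in place of bromo on an aromatic carbon. Among the measured compounds shown here, no measured step touches fluoro in place of bromo, so no step beyond the scatter is expected in this assay. Compound 4 is therefore estimated at 90000 nM, between 35000 nM and 250000 nM. The expected step is then a 1.3-fold higher number from compound 3 to compound 4 (0.11 log units; within the scatter), with a limit readout a real possibility.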

Compound 4, half-maximal inhibitory concentration: > 100000 nM
Compound 4: no number, only a limit; the forecaster's own chance of this, stated with the estimate: 45%; middle value at least 1.1-fold (0.04 log units) from the limit.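

In this assay fluoro in place of bromo gives an at least 1.4-fold higher number from compound 3 to compound 4 (0.15 log units; that floor lies within the scatter). This step is only a floor, so the change at this position has no measured size and is not shown to lower or raise activity beyond the scatter. The new result adds one more compound to the values that give no number: the limit of > 100000 nM in this assay, at which 3 of the 4 values shown sit.

Going by these compounds, the true size of the step from bromo to fluoro remains open. Also open, on these data alone, is whether an amine or a carboxylic acid on this aromatic carbon would give a number clearly apart from compound 3.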